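From compound 3 to compound 4 at the assay limit

The source may report more compounds than this note shows. Statements on the series, on what has been measured and on what is new or still open speak of the compounds shown alone.

In a functional assay on SEM cells (Homo sapiens) for cytotoxicity, with a stated time of 72 h (a lower number here means that less compound is needed, a higher number that more compound is needed for the effect), compound 3 (`C=C[C@@](C)(/C=C/c1ccc(-c2cccc(F)c2)cc1)CCC=C(C)C`) gives > 36600 nM as a limit, not a number. Compound 1 (`C=C[C@@](C)(/C=C/c1ccc(OS(=O)(=O)C(F)(F)F)cc1)CCC=C(C)C`) gives > 36600 nM as a limit too. Compound 2 (`C=C[C@@](C)(/C=C/c1ccc(Nc2ccc(Cl)c(Cl)c2)cc1)CCC=C(C)C`) likewise gives > 36600 nM as a limit. Going by the values given here, the series so far therefore consists of the limit of > 36600 nM in this assay, at which 3 of the 3 values shown sit, and nothing finer.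

Compound 4 (`C=C[C@@](C)(/C=C/c1ccc(-c2ccc(Cl)c(Cl)c2)cc1)CCC=C(C)C`) takes 3,4-dichlorophenyl in place of the 3-fluorophenyl of compound 3, on an aromatic carbon, para to a large group (3,4-dichlorophenyl in place of 3-fluorophenyl on an aromatic carbon).

The closest measured changes at this place are a step that the two limits leave unreadable from compound 1 to compound 3 and a step that the two limits leave unreadable from compound 2 to compound 3 and a step that the two limits leave unreadable from compound 1 to compound 2 in turn. None of them gives a size to carry over, so no direction can be drawn from them. With compound 3 held at > 36600 nM as a limit, no step beyond the scatter is expected. The estimated move is a step that the limit leaves unreadable from compound 3 to compound 4 with little weight on its direction. For compound 4 the expected value is 40000 nM within an estimated range from 12000 nM to 100000 nM and the result will most likely be reported as a limit again.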

Compound 4, half-maximal effective concentration: > 36600 nM
Compound 4: no number, only a limit (the forecaster's own chance of this, stated with the estimate: 80%); the middle value is on the limit's open side.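

Going by these compounds alone, the steps from compound 1, compound 2 and compound 3 to compound 4 cannot be read because the series offers only one limit and no number: the limit of > 36600 nM in this assay, at which 4 of the 4 values shown sit. The compounds shown leave open whether any group on this aromatic carbon gives a measurable value in this assay.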